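Swapping pyrrole for furan on the shared core

A few compounds are considered here, and "the series" means these few. Any claim that something is new, unique, unknown or untested is made for them only; others in the source may bear on it.

Measured in a functional assay on HCT-116 cells (Homo sapiens) for antiproliferative activity, read by sulforhodamine B assay; on this read-out higher numbers stand for weaker inhibition and lower numbers for stronger inhibition:
- compound 1 `CN1CCN(c2ccc(N/C=C3\C(=O)NC(=O)c4ccc(-n5cccc5)cc43)cc2)CC1`: 1500 nM
- compound 2 `O=C1NC(=O)c2ccc(-n3cccc3)cc2/C1=C/Nc1ccc(CN2CCCCC2)cc1`: 2700 nM

Where compound 2 stands is simple: it cannot be told apart from the one other measured compound, with a 1.8-fold higher number from compound 1 to compound 2 (0.26 log units; within the scatter). The next compound, compound 3 `O=C1NC(=O)c2ccc(-c3ccoc3)cc2/C1=C/Nc1ccc(CN2CCCCC2)cc1`, keeps the rest of compound 2 and changes one group: furan-3-yl in place of 1H-pyrrol-1-yl on an aromatic carbon. Both groups are five-membered aromatic rings. Among the compounds with values here, the only measured step concerns a different group, so no measurement shows what this swap does. With no evidence for a shift in either direction, no step beyond the scatter is expected in this assay. The expected change is a 1.1-fold lower number from compound 2 to compound 3 (0.05 log units; within the scatter), which is an estimate only. The estimated value for compound 3 is 2400 nM, with an expected range from 800 nM to 7500 nM.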

Compound 3, half-maximal inhibitory concentration: 1900 nM
Compound 3: middle estimate off by 1.3-fold (0.10 log units), on the high side; the range from low to high includes it.
By their numbers in this assay, from the lowest: compounds 1, 3 and 2 (each within the scatter of the next).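

Within the data shown here, compound 2 and compound 3 give the only measured comparison at this position, since the earlier step concerned a different group. In this assay the swap of 1H-pyrrol-1-yl for furan-3-yl gives a 1.4-fold lower number from compound 2 to compound 3 (0.15 log units; within the scatter) and so the two compounds cannot be told apart, which shows that, on this shared core, this five-membered aromatic ring can carry oxygen instead of nitrogen with no measurable shift in this read-out. Nothing measured here explains why the two compounds read alike.

Still open, as far as these compounds go, is how this aromatic carbon responds to a different kind of group, such as a phenyl ring, an amine or a carboxylic acid. Also open, from the compounds shown here alone, is whether furan-3-yl gives the same result alongside the 4-methylpiperazin-1-yl group of compound 1.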